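A Chlorophenoxy Group in Place of a Long Alkyl Chain

A few compounds are considered here, and "the series" means these few. Any claim that something is new, unique, unknown or untested is made for them only; others in the source may bear on it.

Of the compounds shown here, three have been measured against the same shared core. Compound 1 `CCCCCCCCCCC(C)(C)C(=O)Nc1c(C)c([N+](=O)[O-])c(C)c2c1OC(C)(C)C2` gives 36 nM in an assay for inhibition of acyl-CoA:cholesterol acyltransferase (Oryctolagus cuniculus), using microsomes; a higher number here means a weaker inhibitor, a lower number a stronger inhibitor. Compound 2 `CCCCCCCCCCC1(C(=O)Nc2c(C)ccc3c2OC(C)(C)C3)CCCC1` gives 240 nM in this assay. Compound 3 `CCCCCCCCCCCCC(C)(C)C(=O)Nc1c(C)cc(C)c2c1OC(C)(C)C2` gives 33 nM in this assay. Among the three numbers compound 3 stands lowest, but its gap to compound 1 lies within the usual scatter, so the two cannot be placed in an order; only compound 2 sits clearly apart, with a number well beyond the scatter above that of compound 3.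

Compound 4 `Cc1cc(C)c(NC(=O)C(C)(C)CCCOc2ccc(Cl)cc2)c2c1CC(C)(C)O2` has not yet been measured. It differs from compound 3 by 4-chlorophenoxy in place of nonyl on a saturated chain carbon, four bonds along the chain from a carbonyl carbon. Among the measured compounds shown here, no measured pair in this set shows an exchange of this kind, so any expectation rests on the three values alone and on the fact that the two compounds with the long chain intact, compound 1 and compound 3, give the low numbers, while compound 2 gives the high one. A step toward a higher number, of moderate size and likely beyond the scatter, is therefore expected for compound 4. Compound 4 is estimated at 90 nM, with a range from 25 nM to 350 nM. That estimate means an expected step of a 2.7-fold higher number from compound 3 to compound 4 (0.44 log units; beyond the scatter).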

Compound 4, half-maximal inhibitory concentration: 260 nM
Compound 4: middle estimate off by 2.9-fold (0.46 log units), on the low side; the range from low to high includes it.
By their numbers in this assay, from the lowest: compounds 3 and 1 (each within the scatter of the next); then compounds 2 and 4 (each within the scatter of the next).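

In this assay, among the compounds shown here, 4-chlorophenoxy in place of nonyl on a saturated chain carbon, four bonds along the chain from a carbonyl carbon, gives a 7.9-fold higher number from compound 3 to compound 4 (0.90 log units; beyond the scatter), the first step in this set that isolates a change in one place. It shows that the number at this position depends on what ends the chain: an aromatic ring with an oxygen and a chlorine, replacing a plain carbon chain, moves the number upward by a margin beyond the scatter, although compound 4 still gives a value of 260 nM, so inhibition remains measurable with this group in place. Nothing in the data shown bears on the cause of this step.

From the compounds shown here alone, this single exchange does not separate the parts of the entering group, so it remains open how phenoxy without the chlorine, or a simple phenyl at the chain end, would compare with nonyl and with 4-chlorophenoxy. Also open, going by these compounds, is how a terminal amine or carboxylic acid on the same chain would read, and whether the same exchange gives a step of similar size on the core of compound 1.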